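Expecting a small step from chloro to methyl

A few compounds are considered here, and "the series" means these few. Any claim that something is new, unique, unknown or untested is made for them only; others in the source may bear on it.

Going by the values given here, in an ADME assay on MDCK cells (Canis lupus familiaris) for cytotoxicity, read by MTT assay, with a stated time of 72 h (on this read-out higher numbers stand for lower toxicity in this test and lower numbers for higher toxicity in this test), compound 1 `Cc1nc([N+](=O)[O-])cn1S(=O)(=O)c1ccc(Cl)cc1` gives 578000 nM, at the low end of the three numbers so far. Compound 2 `Cc1nc([N+](=O)[O-])cn1S(=O)(=O)c1ccc([N+](=O)[O-])cc1` gives 611000 nM, which is level with it, and compound 3 `Cc1nc([N+](=O)[O-])cn1S(=O)(=O)c1ccccc1` gives 1270000 nM. Compound 4 `Cc1ccc(S(=O)(=O)n2cc([N+](=O)[O-])nc2C)cc1` has not been measured. It differs from compound 1 in one place: methyl in place of chloro on an aromatic carbon, para to a large group.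

Three measured steps change the same place. Nitro in place of chloro gave a 1.1-fold higher number from compound 1 to compound 2 (0.02 log units; within the scatter). Hydrogen in place of chloro gave a 2.2-fold higher number from compound 1 to compound 3 (0.34 log units; beyond the scatter), and hydrogen in place of nitro gave a 2.1-fold higher number from compound 2 to compound 3 (0.32 log units; beyond the scatter). Only the two changes to hydrogen went beyond the scatter, and both were modest. Among the compounds with values here, no methyl compound has been measured, so methyl could fall anywhere from level with chloro to level with hydrogen. In this assay a small upward step is therefore expected, probably within the scatter. The estimated change is a 1.3-fold higher number from compound 1 to compound 4 (0.11 log units; within the scatter). For compound 4 the expected value is 750000 nM, with an estimated range of 380000 nM to 1500000 nM.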

Compound 4, half-maximal cytotoxic concentration: 988000 nM
For compound 4 the middle estimate is 1.3-fold (0.12 log units) below the measured one; low and high end bracket the measured number.
By their numbers in this assay, from the lowest: compounds 1, 2, 4 and 3 (each within the scatter of the next, the first and the last beyond it).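

In this assay methyl in place of chloro gives a 1.7-fold higher number from compound 1 to compound 4 (0.23 log units; within the scatter) and methyl in place of nitro gives a 1.6-fold higher number from compound 2 to compound 4 (0.21 log units; within the scatter) on the same aromatic carbon. Methyl in place of hydrogen gives a 1.3-fold lower number from compound 3 to compound 4 (0.11 log units; within the scatter) at that place, so the methyl compound cannot be told apart from any of the other three, although compound 1 and compound 3 do stand apart from each other. Nothing available gives a reason for these small differences.

Going by these compounds, whether an amine, a carboxylic acid or a longer chain in this same place would stay this close to the other compounds remains open. So does whether the same swaps would behave alike on another part of the shared core.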